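Moving the Chloro Group Around the Phenyl Ring

This account rests on a few compounds, and the source may have more. Where it says the series, first, only, none or still open, it means among the compounds named here.

Compound 3 `CC(C)N1CCc2nc(C#Cc3cccc(Cl)c3)ccc2C1=O` has the lowest number of the three measured in an assay on HEK293 cells for displacement of a labelled ligand from metabotropic glutamate receptor 5 (Homo sapiens), with a stated time of 2 h (a higher number here means a weaker inhibitor, a lower number a stronger inhibitor), giving 100 nM. Compound 2 `Cc1cccc(C#Cc2ccc3c(n2)CCN(C(C)C)C3=O)c1` gives 510 nM and compound 1 `CC(C)N1CCc2nc(C#Cc3ccccc3)ccc2C1=O` gives 1280 nM. Compound 4 `CC(C)N1CCc2nc(C#Cc3ccc(Cl)cc3)ccc2C1=O` differs from compound 3 by 4-chlorophenyl in place of 3-chlorophenyl on a triple-bonded carbon. Among the measured compounds shown here, none of the measured steps moves a group from one place on the ring to another; the steps that bear on the question show only that a substituent on the ring matters: a 13-fold lower number from compound 1 to compound 3 (1.11 log units; beyond the scatter), a 2.5-fold lower number from compound 1 to compound 2 (0.40 log units; beyond the scatter) and a 5.1-fold lower number from compound 2 to compound 3 (0.71 log units; beyond the scatter). Whether a chloro at the new place keeps that gain is not shown by any measurement, so some loss is expected, as a step of a 6.0-fold higher number from compound 3 to compound 4 (0.78 log units; beyond the scatter). Compound 4 is therefore estimated at 600 nM, within a range from 150 nM to 2500 nM.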

Compound 4, inhibition constant: 27100 nM
The estimate for compound 4 lay 45-fold (1.65 log units) below the measured number, outside the stated range (above it).
By their numbers in this assay, from the lowest: compound 3; then compound 2; then compound 1; then compound 4.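

In this assay, the place of the chloro decides the result: 4-chlorophenyl in place of 3-chlorophenyl gives a 270-fold higher number from compound 3 to compound 4 (2.43 log units; beyond the scatter) and takes the series from its lowest number to its highest. A chloro on the ring therefore does not help in itself, as a 21-fold higher number from compound 1 to compound 4 (1.33 log units; beyond the scatter) shows a loss against the bare phenyl ring, and a 53-fold higher number from compound 2 to compound 4 (1.73 log units; beyond the scatter) shows a loss against 3-methylphenyl as well. No evidence here explains this reversal. Going by these compounds, whether a fluoro, a methoxy or an amine in place of the chloro of compound 4 would bring the same loss remains open.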